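The source may report more compounds than this note shows. Statements on the series, on what has been measured and on what is new or still open speak of the compounds shown alone.

Measured compounds:
Compound 1, `O=C(/C(=C\c1c(-c2ccccc2)[nH]c2ccccc12)S(=O)(=O)c1ccccc1)c1ccccc1`: 10100 nM
Compound 2, `COc1ccc(-c2[nH]c3ccc(OC)cc3c2/C=C(\C#N)S(=O)(=O)c2ccccc2)cc1`: 612 nM
Compound 3, `CC(=O)/C(=C\c1c(-c2ccccc2)[nH]c2ccccc12)S(=O)(=O)c1ccccc1`: 1700 nM

In a functional assay on SNB-75 cells (Homo sapiens) for inhibition, read by sulforhodamine B assay, with a stated time of 48 h (on this read-out higher numbers stand for weaker inhibition of growth and lower numbers for stronger inhibition of growth), compound 2 gives the lowest of the three numbers. Its nearest neighbour is compound 3, with 1700 nM, and the furthest is compound 1, with 10100 nM. Among the compounds with values here, the only step between compounds that differ in one place is a 5.9-fold lower number from compound 1 to compound 3 (0.77 log units; beyond the scatter), and it concerns the group on the carbonyl carbon, not the fused ring system.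

Compound 4, `COc1ccc(-c2[nH]c3ccccc3c2/C=C(\C#N)S(=O)(=O)c2ccccc2)cc1`, differs from compound 2 in one place: hydrogen in place of methoxy on an aromatic carbon. Within the data shown here, no measured pair shows what this change does in this assay, so the account can lean on no step of the kind; the nitrile and the methoxy on the phenyl ring remain in place. Under these conditions a small step, if any, is expected, and a number slightly above that of compound 2 is estimated, that is a 1.5-fold higher number from compound 2 to compound 4 (0.17 log units; within the scatter). For compound 4 the expected value in this assay is 900 nM, with a range from 350 nM to 2500 nM.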

Compound 4, concentration for 50% growth inhibition: 379 nM
For compound 4 the middle estimate is 2.4-fold (0.38 log units) above the measured one; the measured number falls inside the stated range.
By their numbers in this assay, from the lowest: compounds 4 and 2 (each within the scatter of the next); then compound 3; then compound 1.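

In this assay, the step to hydrogen at this aromatic carbon, part of a fused or bridged system of two rings, is a 1.6-fold lower number from compound 2 to compound 4 (0.21 log units; within the scatter), so the methoxy here can be lost without a change that exceeds the scatter. Within the data shown here, this is the first view of this position, as the only earlier step concerned the group on a carbonyl carbon and left the fused ring system untouched. Nothing available here bears on the reason for this result.

The compounds shown leave open whether an amine, a carboxylic acid or a longer chain such as propoxy at this position would also stay within the scatter. They also leave open whether methoxy at this position would have a similarly small effect on the core of compound 3, which carries hydrogen there.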